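What replacing the formyl of compound 3 may do

The source may report more compounds than this note shows. Statements on the series, on what has been measured and on what is new or still open speak of the compounds shown alone.

Measured in an ADME assay on cells (Erythrocyte, Homo sapiens), read by spectrophotometry and hemolysis, with a stated time of 24 h (on this read-out lower numbers stand for stronger inhibition and higher numbers for weaker inhibition), with every value a limit:
Compound 1 `N=C(N)N/N=C/c1ccc(OCc2ccc3no[n+]([O-])c3c2)cc1`: > 200 uM
Compound 2 `O=Cc1ccc(OCc2ccc3no[n+]([O-])c3c2)cc1`: < 50 uM
Compound 3 `O=Cc1ccccc1OCc1ccc2no[n+]([O-])c2c1`: > 100 uM

Compound 3 stands at the limit of > 100 uM in this assay, at which 1 of the 3 values shown sits, so it has a limit and no exact number. Compound 4 `C/C(=N/NC(=N)N)c1ccccc1OCc1ccc2no[n+]([O-])c2c1` differs from it by one exchange: a group of 7 heavy atoms (3 carbon, 4 nitrogen; no ring) in place of a group of 2 heavy atoms (1 carbon, 1 oxygen; no ring), on an aromatic carbon. The formyl leaves, and the new group sits ortho to a large group.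

Within the data shown here, only one measured step bears on this exchange: an at least 4.0-fold lower number from compound 1 to compound 2 (0.60 log units; beyond the scatter). That step lies beyond the scatter, and both of its ends are limits. There the formyl enters, whereas here it leaves, so the sense of the exchange is reversed. The two changes are also not the same, since the group that the formyl replaces there is not the group that replaces it here. Read in reverse, an at least 4.0-fold lower number from compound 1 to compound 2 (0.60 log units; beyond the scatter) leads to the expectation of a higher number for compound 4 in this assay, meaning weaker inhibition.

The expected change is a step that the limit leaves unreadable from compound 3 to compound 4, a rough estimate given that it starts from a limit. Compound 4 is expected near 250 uM, with an estimated range of 120 uM to 500 uM.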

Compound 4, concentration for 50% inhibition: > 200 uM
Compound 4: only a limit was reported; the forecaster's own chance of this, stated with the estimate: 75%; the middle value does not contradict the limit.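

In this assay, among these compounds, compound 3 and compound 4 are each reported only as a limit, so no step between them can be read. The compounds shown leave open whether exchanging the formyl for the new group changes the number at all, and, if it does, in which direction and by how much.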